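Pyrimidine for Pyridine on the Vinyl Sulfone Core

The source may report more compounds than this note shows. Statements on the series, on what has been measured and on what is new or still open speak of the compounds shown alone.

Compound 1 `COc1cccc(S(=O)(=O)/C=C/c2cccnc2)c1` is the weaker of the two measured compounds here: in an assay on U2OS cells for activation of nuclear factor erythroid 2-related factor 2 (Homo sapiens), read by chemiluminescence, with a stated time of 6 h (on this read-out higher numbers stand for an effect only at larger amounts of compound and lower numbers for an effect already at smaller amounts), compound 1 gives 6290 nM, the highest of the two numbers. Among the measured compounds shown here, its only measured neighbour is compound 2 `COc1cccc(S(=O)(=O)/C=C/c2cccnc2Cl)c1`, which in this assay gives 348 nM; that step, an 18-fold lower number from compound 1 to compound 2 (1.26 log units; beyond the scatter), comes from chloro in place of hydrogen on an aromatic carbon.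

Compound 3 `COc1cccc(S(=O)(=O)/C=C/c2cncnc2)c1` takes a different route from compound 1: pyrimidin-5-yl in place of pyridin-3-yl on a double-bonded chain carbon bound to a double-bonded chain carbon. For the measured compounds named here, no measured step follows this exchange; the one step in hand concerns a halogen on the ring, not a change of the ring itself, so it does not carry over to compound 3. Without a comparable step, the reasonable expectation is no movement beyond the scatter, with a 1.1-fold lower number from compound 1 to compound 3 (0.06 log units; within the scatter) as the estimated step in this assay.

Compound 3 is therefore expected to give about 5500 nM in this assay, with a range from 1500 nM to 18000 nM once it is measured.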

Compound 3, half-maximal effective concentration: 7380 nM
Compound 3: middle estimate off by 1.3-fold (0.13 log units), on the low side; the range from low to high includes it.
By their numbers in this assay, from the lowest: compound 2; then compounds 1 and 3 (each within the scatter of the next).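

In this assay, a ring with 2 hetero atoms takes the place of one with 1 hetero atom, and the result is a 1.2-fold higher number from compound 1 to compound 3 (0.07 log units; within the scatter), so this exchange of the whole ring leaves the read-out within the scatter. Until now the only change shown at this end of the molecule was chloro in place of hydrogen on an aromatic carbon, which gave an 18-fold lower number from compound 1 to compound 2 (1.26 log units; beyond the scatter); the new result shows that pyrimidin-5-yl can stand in place of pyridin-3-yl on a double-bonded chain carbon bound to a double-bonded chain carbon without a movement beyond the scatter. Nothing available speaks to the reason for this result.

Still open is whether chloro on pyrimidin-5-yl would give a step of the size seen with chloro on pyridin-3-yl, as the compounds shown carry the two changes only separately. Also open, going by these compounds, is what an amine or a carboxylic acid on either ring would do in this assay, in place of chloro or of hydrogen.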